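Neopentyl for (4-fluorophenyl)carbonyl on the ring nitrogen

This account rests on a few compounds, and the source may have more. Where it says the series, first, only, none or still open, it means among the compounds named here.

Three compounds share a core and differ only at an amine nitrogen in a ring. Compound 1 `[O-][S+](CCNC1CCN(Cc2ccc(F)cc2)CC1)C(c1ccc(F)cc1)c1ccc(F)cc1` carries a 4-fluorobenzyl there; in an assay on membranes from striatum (strain Sprague-Dawley) for displacement of a labelled ligand from sodium-dependent dopamine transporter (Rattus norvegicus), read by scintillation counting, with a stated time of 120 min (a lower number here means a stronger inhibitor, a higher number a weaker inhibitor), compound 1 gives 50.6 nM. Compound 2 `O=C(c1ccccc1)N1CCC(NCC[S+]([O-])C(c2ccc(F)cc2)c2ccc(F)cc2)CC1` carries benzoyl and gives 79.1 nM in this assay. Compound 3 `O=C(c1ccc(F)cc1)N1CCC(NCC[S+]([O-])C(c2ccc(F)cc2)c2ccc(F)cc2)CC1` carries (4-fluorophenyl)carbonyl and gives 77.2 nM in this assay, the second highest of the three numbers shown, though all three sit within the scatter of one another. The measured steps are a 1.6-fold higher number from compound 1 to compound 2 (0.19 log units; within the scatter), a 1.5-fold higher number from compound 1 to compound 3 (0.18 log units; within the scatter) and a 1.0-fold lower number from compound 2 to compound 3 (0.01 log units; within the scatter); none of them leaves the scatter.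

Compound 4 `CC(C)(C)CN1CCC(NCC[S+]([O-])C(c2ccc(F)cc2)c2ccc(F)cc2)CC1` is not yet measured. Its change from compound 3 is neopentyl in place of (4-fluorophenyl)carbonyl on an amine nitrogen in a ring. Within the data shown here, no measured step exchanges an aromatic group on this nitrogen for an acyclic alkyl; the steps at hand show only that swapping 4-fluorobenzyl for either carbonyl group, or fluoro for hydrogen, keeps the number within the scatter. Among the measured compounds shown here, a step of similar small size is therefore expected in this assay, with no firm direction, and with wider uncertainty since the new group has no measured counterpart. The estimate for compound 4 in this assay is 65 nM, between 25 nM and 180 nM. This expected step is a 1.2-fold lower number from compound 3 to compound 4 (0.07 log units; within the scatter).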

Compound 4, inhibition constant: 431 nM
For compound 4 the middle estimate is 6.6-fold (0.82 log units) below the measured one, outside the stated range (above it).
By their numbers in this assay, from the lowest: compounds 1, 3 and 2 (each within the scatter of the next); then compound 4.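

In this assay, among these compounds, this ring nitrogen proves sensitive to its substituent: neopentyl gives a 5.6-fold higher number from compound 3 to compound 4 (0.75 log units; beyond the scatter) and a 5.4-fold higher number from compound 2 to compound 4 (0.74 log units; beyond the scatter), the first steps at this position beyond the scatter, whereas the 4-fluorobenzyl, benzoyl and (4-fluorophenyl)carbonyl groups of the earlier compounds could not be told apart. Read as tert-butyl in place of 4-fluorophenyl on the saturated chain carbon bound to the ring nitrogen, the change gives an 8.5-fold higher number from compound 1 to compound 4 (0.93 log units; beyond the scatter), so among these four compounds the weaker number goes with the one group that has no ring, with or without a carbonyl on the other three. Nothing on hand accounts for this loss. 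

On these data alone, it remains open whether the aromatic ring itself matters or whether a saturated ring, as in cyclohexylmethyl, would serve equally well on this nitrogen. Also unsettled is how far the number depends on the size and shape of the alkyl group, which a straight chain such as n-pentyl or a smaller group such as ethyl would help to separate.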